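This account rests on a few compounds, and the source may have more. Where it says the series, first, only, none or still open, it means among the compounds named here.

Compound 1 `O=C(NO)c1ccc(Cn2c(=O)c(O)c(-c3ccccc3)c3ccccc32)cc1` gives 308 nM in an assay on Sf9 cells for inhibition of protein deacetylase HDAC6 (Homo sapiens), read by fluorescence, with a stated time of 90 min; on this read-out higher numbers stand for weaker inhibition and lower numbers for stronger inhibition. Compound 2 `O=C(NO)c1ccc(Cn2c(=O)c(O)c(-c3cccnc3)c3ccccc32)cc1` gives 296 nM in this assay. The change between them, (pyridin-3-yl in place of phenyl on an aromatic carbon), produced a 1.0-fold lower number from compound 1 to compound 2 (0.02 log units; within the scatter). Compound 3 `Cn1c(=O)c(OCc2ccc(C(=O)NO)cc2)c(-c2ccccc2)c2ccccc21` has a different core, and the difference between the two cores is not broken down here; in this assay compound 3 gives 519 nM. Compound 4 `Cn1c(=O)c(OCc2ccc(C(=O)NO)cc2)c(-c2cccnc2)c2ccccc21` is not yet measured and carries the same kind of change as before, (pyridin-3-yl in place of phenyl on an aromatic carbon). The surroundings differ: in compound 1 the place is ortho to a hydroxy group and para to a large group, whereas in compound 3 it is ortho to a large group and para to a methyl group. Resting on compound 1 and compound 2, where the step was a 1.0-fold lower number from compound 1 to compound 2 (0.02 log units; within the scatter), the expected step is a 1.0-fold lower number from compound 3 to compound 4 (0.02 log units; within the scatter). Compound 4 is therefore estimated at 500 nM, expected to lie between 250 nM and 1000 nM.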

Compound 4, half-maximal inhibitory concentration: 46 nM
The estimate for compound 4 lay 11-fold (1.04 log units) above the measured number; measured number below the stated range.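

In this assay, putting pyridin-3-yl in place of phenyl gave an 11-fold lower number from compound 3 to compound 4 (1.05 log units; beyond the scatter), so the change did not carry over at the same size from one core to the other: the same change on two cores in this assay, a 1.0-fold lower number (0.02 log units; within the scatter) from compound 1 to compound 2 and an 11-fold lower number (1.05 log units; beyond the scatter) from compound 3 to compound 4, 11-fold (1.04 log units) apart, beyond the scatter of two such steps

In this series, then, a step measured on one core was a poor guide to the same step on the other. These two pairs do not show which difference between the cores lies behind this, nor how the step would run on a third core.

As far as these compounds go, it remains open whether pyridin-4-yl, or a phenyl carrying an amine, would give a similar step at this place on the core of compound 3. From the compounds shown here alone, it also remains open whether the step would hold against other deacetylases.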